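The compounds below may be only part of what the source reports. "The series", "measured", "known", "first", "only" and "open" are said of these compounds alone.

Compound 1 `COc1ccc(-n2ccc(=O)c(C(=O)Nc3ccc(Oc4ccnc5[nH]ccc45)cc3)n2)cc1` and compound 2 `COc1ccc(-n2ccc(=O)c(C(=O)Nc3ccc(Oc4ccnc5[nH]ccc45)c(F)c3)n2)cc1` share one core; compound 3 `Cc1cc(=O)n(-c2ccc(F)cc2)nc1C(=O)Nc1ccc(Oc2ncnc3[nH]ccc23)cc1` and compound 4 `Cc1cc(=O)n(-c2ccc(F)cc2)nc1C(=O)Nc1ccc(Oc2ncnc3[nH]ccc23)c(F)c1` share another, and the difference between the two cores is not broken down here. In a functional assay on MCF7 cells (Homo sapiens) for cytotoxicity, read by MTT assay, with a stated time of 72 h (a higher number here means a weaker inhibitor, a lower number a stronger inhibitor), compound 1 gives 21600 nM, compound 2 gives 55400 nM and compound 3 gives 4800 nM. The change from compound 1 to compound 2, (fluoro in place of hydrogen on an aromatic carbon), gives a 2.6-fold higher number from compound 1 to compound 2 (0.41 log units; beyond the scatter). The same change is made from compound 3 to compound 4, (fluoro in place of hydrogen on an aromatic carbon), at a place described in the same words. Compound 3 has the lowest number of the three measured. Going by the values given here, for compound 4 a step of about the earlier size is expected, a 2.5-fold higher number from compound 3 to compound 4 (0.40 log units; beyond the scatter), resting on the single measured instance from compound 1 to compound 2 on a different core. Compound 4 is therefore estimated at 12000 nM, with a likely range from 5500 nM to 30000 nM.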

Compound 4, half-maximal inhibitory concentration: 24500 nM
Beside the measured number, compound 4's estimate is 2.0-fold (0.31 log units) below it, within the range that was stated.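

In this assay, fluoro in place of hydrogen on an aromatic carbon again gives a higher number, with a 5.1-fold higher number from compound 3 to compound 4 (0.71 log units; beyond the scatter), so the direction of the step carries over to the second core, and the two sizes cannot be told apart: the same change on two cores in this assay, a 2.6-fold higher number (0.41 log units; beyond the scatter) from compound 1 to compound 2 and a 5.1-fold higher number (0.71 log units; beyond the scatter) from compound 3 to compound 4, 2.0-fold (0.30 log units) apart, within the scatter of two such steps. One common step therefore fits both cores in this series. Two pairs do not show that it would hold on further cores, and they do not explain why the number rises.

Open, from the compounds shown here alone, is whether another group at this aromatic carbon, such as chloro or an amine, would give a step like that of fluoro. Also open, going by these compounds, is how the fluoro step reads on a core carrying a carboxylic acid or a longer chain.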